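The compounds below may be only part of what the source reports. "The series", "measured", "known", "first", "only" and "open" are said of these compounds alone.

Of the compounds shown here, three that share one core have numbers so far in a toxicity assay on HepG2 2.2.15 cells (Homo sapiens) for cytotoxicity, read by CellTiter-Glo (on this read-out lower numbers stand for higher toxicity in this test and higher numbers for lower toxicity in this test), on record. Compound 1 (`O=C1CC(Oc2ncc(F)cn2)CN1c1cnn2c1CN(C(=O)Nc1cc(F)c(F)c(F)c1)C(C1CC1)C2`) reads 96200 nM on this test. Compound 2 (`CC1(C)CC(=O)N(c2cnn3c2CN(C(=O)Nc2cc(F)c(F)c(F)c2)C(C2CC2)C3)C1`) reads 115000 nM on this test. Compound 3 (`O=C1CC(c2ccc(F)cn2)CN1c1cnn2c1CN(C(=O)Nc1cc(F)c(F)c(F)c1)C(C1CC1)C2`) reads 38500 nM and is the lowest of the three, beyond the scatter from both of the others.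

Compound 4 (`Cc1nc(C2CC(=O)N(c3cnn4c3CN(C(=O)Nc3cc(F)c(F)c(F)c3)C(C3CC3)C4)C2)no1`) differs from compound 3 in one place. On a saturated ring carbon of a five-membered non-aromatic ring with 1 nitrogen, 5-methyl-1,2,4-oxadiazol-3-yl stands in place of 5-fluoropyridin-2-yl (5-methyl-1,2,4-oxadiazol-3-yl in place of 5-fluoropyridin-2-yl on a saturated ring carbon).

Within the data shown here, one measured step bears directly on this carbon: a 2.5-fold lower number from compound 1 to compound 3 (0.40 log units; beyond the scatter) is modest, and it came with 5-fluoropyridin-2-yl in place of (5-fluoropyrimidin-2-yl)oxy. Compound 2, with a different group again at that carbon, also reads higher than compound 3. Three compounds are thin ground, and none of them carries the new group, but leaving 5-fluoropyridin-2-yl has so far meant a higher number. A modest rise is therefore expected, and the estimated change is a 1.9-fold higher number from compound 3 to compound 4 (0.29 log units; within the scatter) on this reasoning. For compound 4 the estimated value is 75000 nM within an expected range of 32000 nM to 150000 nM in this assay.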

Compound 4, half-maximal cytotoxic concentration: > 200000 nM
Compound 4: a limit, no number; the forecaster's own chance of this, stated with the estimate: 15%; middle value at least 2.6-fold (0.42 log units) away from the limit.
By their numbers in this assay, from the lowest: compound 3; then compounds 1 and 2 (each within the scatter of the next). At a limit, above all of these: compound 4.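

Compound 4 gives a limit of the assay in this assay, not a number: the limit of > 200000 nM in this assay, at which 1 of the 4 values shown sits. Among these compounds, with that limit as a floor, this saturated ring carbon proves able to carry much more of the read-out than the earlier compounds showed, with an at least 5.1-fold higher number from compound 3 to compound 4 (0.71 log units; beyond the scatter), and the change also clears the scatter against the group that is linked through oxygen, with an at least 2.0-fold higher number from compound 1 to compound 4 (0.31 log units; beyond the scatter). Against the 4,4-dimethyl compound there is an at least 1.7-fold higher number from compound 2 to compound 4 (0.24 log units; that floor lies within the scatter), so among these four compounds the 5-fluoropyridin-2-yl group stays alone at the low end, while the 5-methyl-1,2,4-oxadiazol-3-yl group gives the reading furthest toward lower toxicity in this test.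

This single swap changes the ring size, the hetero atoms and the methyl together, so the compounds shown cannot say which of these carries the step, and the limit hides how far compound 4 really lies from the others. A plain phenyl or an amine on the same carbon would help to show whether the low number of compound 3 belongs to its pyridine ring or to the fluorine on it.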